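The compounds below may be only part of what the source reports. "The series", "measured", "known", "first", "only" and "open" are said of these compounds alone.

Measured compounds:
compound 1 `CN1CC2(C1)CN(c1ccc(OCc3ccccc3)c(C(=O)Nc3ccnnc3)c1)C2`, 198000 nM
compound 2 `CN1CCC(c2ccc(OCc3ccccc3)c(C(=O)Nc3ccnnc3)c2)CC1`, 71000 nM
compound 3 `O=C(Nc1ccnnc1)c1cc(N2CCC(O)CC2)ccc1OCc1ccccc1`, 28000 nM

In a physicochemical assay for solubility, measured as kinetic solubility (on this read-out lower numbers stand for lower solubility and higher numbers for higher solubility), compound 1 gives the highest number of the three measured compounds; compound 2 and compound 3 both lie beyond the scatter below it, as the steps of a 2.8-fold lower number from compound 1 to compound 2 (0.45 log units; beyond the scatter) and a 7.1-fold lower number from compound 1 to compound 3 (0.85 log units; beyond the scatter) show, and between the two smaller compounds the step of a 2.5-fold lower number from compound 2 to compound 3 (0.40 log units; beyond the scatter) was also beyond the scatter.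

Compound 4 `O=C(Nc1ccnnc1)c1cc(N2CCCCC2)ccc1OCc1ccccc1` has not yet been measured in this assay. It differs from compound 1 in one place: a group of 6 heavy atoms (5 carbon, 1 nitrogen; one six-membered non-aromatic ring with 1 hetero atom) in place of a group of 8 heavy atoms (6 carbon, 2 nitrogen; 2 four-membered non-aromatic rings with 1 hetero atom each), on an aromatic carbon. The two measured steps from compound 1 bear on this change, since each also replaces the same group at the same aromatic carbon with a six-membered ring. Both were modest and both went downward; the step to compound 3, whose entering ring carries a hydroxyl, was the larger. Compound 4 brings a ring with neither a methylated nitrogen nor a hydroxyl, so a downward step at least as large as the step to compound 3 is expected, a 17-fold lower number from compound 1 to compound 4 (1.22 log units; beyond the scatter). Compound 4 is therefore estimated at 12000 nM, within a range from 3000 nM to 40000 nM.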

Compound 4, solubility: 60000 nM
Compound 4: the middle estimate sits 5.0-fold (0.70 log units) below what was measured; the whole stated range lies below it.
By their numbers in this assay, from the lowest: compound 3; then compounds 4 and 2 (each within the scatter of the next); then compound 1.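

In this assay, the unsubstituted piperidin-1-yl at this aromatic carbon, para to a benzyloxy group, still falls beyond the scatter under the group of compound 1, with a 3.3-fold lower number from compound 1 to compound 4 (0.52 log units; beyond the scatter), while a 1.2-fold lower number from compound 2 to compound 4 (0.07 log units; within the scatter) leaves the attachment through the ring nitrogen and the 1-methylpiperidin-4-yl group indistinguishable here. The hydroxy group now has its own one-place comparison, and a 2.1-fold higher number from compound 3 to compound 4 (0.33 log units; beyond the scatter) shows that, in this single pair, replacing it with hydrogen goes with a higher number. No evidence is available to explain any of these differences.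

The compounds shown leave open how a piperazin-1-yl or morpholin-4-yl group would compare at this carbon. They also leave open whether a carboxylic acid or a primary amine on the piperidine ring would move the number in the same direction as the hydroxy group.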